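From Bromo to Fluoro: Expected Cytotoxicity of Compound 3

The source may report more compounds than this note shows. Statements on the series, on what has been measured and on what is new or still open speak of the compounds shown alone.

Compound 1, `COc1nc2ccccc2cc1/C=C/c1noc(-c2ccc(C)cc2)n1`: > 230000 nM
Compound 2, `COc1nc2ccccc2cc1/C=C/c1noc(-c2ccc(Br)cc2)n1`: > 195000 nM

In an ADME assay on HepG2 cells (Homo sapiens) for cytotoxicity, read by sulforhodamine B assay, with a stated time of 48 h (on this read-out higher numbers stand for lower toxicity in this test and lower numbers for higher toxicity in this test), compound 1 gives > 230000 nM, which is a limit of the assay and not a number. Compound 2 gives > 195000 nM in this assay, again a limit. Going by the values given here, the one measured step, a step that the two limits leave unreadable from compound 1 to compound 2, therefore has no readable size: both values sit at limits, the limit of > 195000 nM in this assay, at which 1 of the 2 values shown sits, and (the limit of > 230000 nM in this assay, at which 1 of the 2 values shown sits), so no change in toxicity can be placed on bromo in place of methyl. Among the compounds with values here, compound 2 thus stands at a limit, and the only other value shown is a limit too.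

Compound 3, `COc1nc2ccccc2cc1/C=C/c1noc(-c2ccc(F)cc2)n1`, differs from compound 2 by fluoro in place of bromo on an aromatic carbon. No measured step addresses this change, and the one step shown gives no size at all. With both neighbours showing no measurable toxicity, the step that the limit leaves unreadable from compound 2 to compound 3 is expected to be none beyond the scatter, most likely ending at another limit. Compound 3 is estimated to give 250000 nM, within 100000 nM to 600000 nM.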

Compound 3, half-maximal cytotoxic concentration: > 230000 nM
Compound 3: no number, only a limit (the forecaster's own chance of this, stated with the estimate: 85%); the middle value does not contradict the limit.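

Going by these compounds alone, compound 1, compound 2 and compound 3 each give only a limit of the assay, not a number, in this assay, so no step among them can be read. The compounds shown leave open whether any group at this place changes toxicity in this test.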